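A Small Swap at the Far End of Compound 3

A few compounds are considered here, and "the series" means these few. Any claim that something is new, unique, unknown or untested is made for them only; others in the source may bear on it.

Of the compounds shown here, three have so far been measured in a functional assay on the whole organism (Abdomen, strain Swiss) for inhibition, with Mus musculus as the target, with stated times of 30 min, 10 min and 5 min, at a dose of 10 mg/kg by the oral route; on this read-out higher numbers stand for a stronger effect at the one dose given and lower numbers for a weaker effect. Compound 1 `CCC(=O)c1c(C)nn(CCCN2CCN(c3ccc(C)cc3)CC2)c(=O)c1N` gives 9%. Compound 2 `COc1cccc(N2CCN(CCCn3nc(-c4ccccc4)c(C#N)c3C)CC2)c1` gives 0%, and compound 3 `CC(=O)c1cccn1CCCN1CCN(c2ccc(F)cc2)CC1` gives 0%. Compound 3 stands level with compound 2 at the digits shown; together they are the lowest of the three numbers, and the gap to compound 1 lies within the scatter, so no order among the three can be claimed.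

Compound 4 `CC(=O)c1cccn1CCCN1CCN(c2ccc(C)cc2)CC1` has not yet been measured. It differs from compound 3 in one place: methyl in place of fluoro on an aromatic carbon. One heavy atom replaces another on the same aromatic carbon, with no change in ring count, donors, acceptors or charge.

Among the measured compounds shown here, no measured pair in this set shows this change, so nothing here supports a direction. Because compound 3 gives 0% and all measured compounds sit within the scatter of each other, the expected step is a number 4 percentage points higher from compound 3 to compound 4 (within the scatter), no larger than the scatter. For compound 4 the estimate is 4%, with a range from 0% to 18%.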

Compound 4, a percentage reported as inhibition, in the whole organism at one dose (the size of the read-out at that dose, not a potency): 12%
The estimate for compound 4 lay 8 percentage points below the measured number; measured number inside the range.
By their numbers in this assay, from the lowest: compounds 2, 3, 1 and 4 (each within the scatter of the next, the first and the last beyond it).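

In this assay, among the compounds shown here, methyl in place of fluoro on the aromatic carbon para to a large group gives a number 12 percentage points higher from compound 3 to compound 4 (beyond the scatter), the first step in this set that can be read across a single change. This shows that the position is not silent: with the rest of the structure unchanged, going from 4-fluorophenyl to 4-methylphenyl moves the read-out at the one dose given, although it says nothing about potency. No measurement offered here accounts for the step.

Going by these compounds, whether an ethyl group, a chlorine atom or an amine on the same aromatic carbon would raise the read-out further or take it back remains open. This is also a single pair, so it cannot show whether the same change would give a similar step on another core.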